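This account rests on a few compounds, and the source may have more. Where it says the series, first, only, none or still open, it means among the compounds named here.

Measured in an ADME assay on L6 cells (Rattus norvegicus) for cytotoxicity, read by resazurin assay, with a stated time of 72 h; on this read-out lower numbers stand for stronger inhibition and higher numbers for weaker inhibition:
- compound 1 `CN(C)C12CC(OC(=O)CN3CCCC3)C(C(c3ccccc3)C1)C(c1ccccc1)C2`: 32700 nM
- compound 2 `CN1CCN(CC(=O)OC2CC3(N4CCCCC4)CC(c4ccccc4)C2C(c2ccccc2)C3)CC1`: 29500 nM
- compound 3 `O=C(CN1CCCCC1)OC1CC2(N3CCCCC3)CC(c3ccccc3)C1C(c1ccccc1)C2`: 60400 nM

All three numbers are high, and they lie close together. Compound 3, at 60400 nM, sits within the usual scatter of compound 1, at 32700 nM. Its separation from compound 2 is modest but real: a 2.0-fold higher number from compound 2 to compound 3 (0.31 log units; beyond the scatter).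

The next molecule, compound 4 `O=C(CN1CCCC1)OC1CC2(N3CCCCC3)CC(c3ccccc3)C1C(c1ccccc1)C2`, keeps the core of compound 3 and alters one group: pyrrolidin-1-yl in place of piperidin-1-yl on a saturated chain carbon bound to a carbonyl carbon. Counted out, the change is pyrrolidin-1-yl in place of piperidin-1-yl on a saturated chain carbon bound to a carbonyl carbon.

Only one measured step touches this place, the modest one from compound 2 to compound 3 given above, and it involves a different pair of groups. It therefore suggests that changes here move this assay only a little. Compound 4 would also share pyrrolidin-1-yl at this place with compound 1, which differs elsewhere in the molecule and gives 32700 nM. That value hints at a slight drop, but no step beyond the scatter is expected.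

Expected, then, is a 1.3-fold lower number from compound 3 to compound 4 (0.13 log units; within the scatter). For compound 4 the estimated value is 45000 nM, with an expected range from 22000 nM to 90000 nM.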

Compound 4, half-maximal inhibitory concentration: 16400 nM
Compound 4: middle estimate off by 2.7-fold (0.44 log units), on the high side, outside the stated range (below it).
By their numbers in this assay, from the lowest: compounds 4, 2, 1 and 3 (each within the scatter of the next, the first and the last beyond it).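

In this assay, for the compounds shown here, the place on the saturated chain carbon bound to a carbonyl carbon turns out to respond more than the single earlier step there suggested: taking one carbon out of the ring, going from piperidin-1-yl to pyrrolidin-1-yl, gives a 3.7-fold lower number from compound 3 to compound 4 (0.57 log units; beyond the scatter) and moves the number clearly. Pyrrolidin-1-yl and 4-methylpiperazin-1-yl, by contrast, cannot be told apart at this place (a 1.8-fold lower number from compound 2 to compound 4 (0.25 log units; within the scatter)), so among these three groups on this core piperidin-1-yl alone stands apart from the other two. Going from dimethylamino to piperidin-1-yl on a saturated ring carbon gives no readable shift (a 2.0-fold lower number from compound 1 to compound 4 (0.30 log units; within the scatter)), and no measurement offered here explains any of these steps.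

The three ring amines shown leave open where an open-chain amine such as diethylamino, or a ring such as morpholin-4-yl, would fall at this place. Also open, going by these compounds, is whether the gap between piperidin-1-yl and pyrrolidin-1-yl on the chain would hold with dimethylamino on the saturated ring carbon.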